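Chlorine position on the pyridyl amine in the shared series

The source may hold more compounds than are shown below. What is called first, only, known or untested is meant among the compounds shown, and "the series" means these compounds.

Of the compounds shown here, three of the shared core have been measured in an assay on MDA-MB-231 cells for displacement of a labelled ligand from C-X-C chemokine receptor type 4 (Homo sapiens); on this read-out higher numbers stand for an effect only at larger amounts of compound and lower numbers for an effect already at smaller amounts. Compound 1 `c1ccc(NCc2ccc(CNc3ncccn3)cc2)cc1` gives 10 nM. Compound 2 `COc1ncc(F)c(NCc2ccc(CNc3nc(OC)ncc3F)cc2)n1` gives 1 nM. For the measured compounds named here, compound 3 `Clc1cccc(NCc2ccc(CNc3ncccn3)cc2)n1` gives 1 nM, level with compound 2 at the digits printed and together with it the lowest of the three numbers; its only measured neighbour by a single change is compound 1, from which it differs by a 10-fold lower number from compound 1 to compound 3 (1.00 log units; beyond the scatter).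

Compound 4 `Clc1ccc(NCc2ccc(CNc3ncccn3)cc2)nc1` has not yet been measured. It differs from compound 3 by 5-chloropyridin-2-yl in place of 6-chloropyridin-2-yl on an amine nitrogen.

Going by the values given here, no measured step moves the chlorine around the same ring, so the only step that bears on this change is the one from phenyl to the chlorinated pyridyl, a 10-fold lower number from compound 1 to compound 3 (1.00 log units; beyond the scatter), which shows that a chlorinated pyridyl on this nitrogen is well tolerated. Moving the chlorine within that ring is a smaller change than adding it, and the expected step of a 2.0-fold higher number from compound 3 to compound 4 (0.30 log units; within the scatter) is therefore small, possibly a modest rise in the number, but most likely not beyond the scatter. Compound 4 is expected to give about 2 nM in this assay, with a range of 0.5 nM to 8 nM.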

Compound 4, effective concentration (reported as EC, without a stated level of effect): 10 nM
For compound 4 the middle estimate is 5.0-fold (0.70 log units) below the measured one; the measured number lies above the stated range.
By their numbers in this assay, from the lowest: compounds 2 and 3 (each within the scatter of the next); then compounds 1 and 4 (each within the scatter of the next).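

Read in this assay, the step from 6-chloropyridin-2-yl to 5-chloropyridin-2-yl on this amine nitrogen is large despite the same atoms and the same counts of donors and acceptors (a 10-fold higher number from compound 3 to compound 4 (1.00 log units; beyond the scatter)). The earlier drop on leaving phenyl (a 10-fold lower number from compound 1 to compound 3 (1.00 log units; beyond the scatter)) therefore belongs to 6-chloropyridin-2-yl and does not extend to chloropyridyl groups in general, since 5-chloropyridin-2-yl in place of phenyl leaves the number unmoved (no change at the digits printed from compound 1 to compound 4 (within the scatter)). No measurement at hand accounts for the difference between the two chlorine placements.

The compounds shown leave open whether the low number of compound 3 depends on the chlorine itself or on the chlorine together with the ring nitrogen; unsubstituted pyridin-2-yl, 6-methylpyridin-2-yl and 6-methoxypyridin-2-yl on the same amine nitrogen would separate these readings. Also open, as far as these compounds go, is whether the gap between the 6-chloropyridin-2-yl and 5-chloropyridin-2-yl groups persists when the other amine nitrogen of the shared core carries a different aromatic group.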